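Working notes: aryl exchange and microsomal clearance in one series

The compounds below may be only part of what the source reports. "The series", "measured", "known", "first", "only" and "open" are said of these compounds alone.

Measured so far:
Compound 1 `CNc1nc(NCCCN(C)C)c2sc(-c3ccc(S(C)(=O)=O)cc3)cc2n1` gives 15 uL/min in an ADME assay (liver) for metabolic stability, with Liver microsome (Homo sapiens) as the target, read by LC-MS, using microsomes, tested at 1 uM; on this read-out lower numbers stand for slow clearance and higher numbers for fast clearance.
Compound 2 `CNc1nc(NCCCN(C)C)c2sc(-c3ccc(C(C)=O)cc3)cc2n1` gives 81 uL/min in this assay.
Compound 3 `CNc1nc(NCCCN(C)C)c2sc(-c3ccc(N4CCNCC4)cc3)cc2n1` gives 36 uL/min in this assay.

Compound 2 stands highest of the three numbers. Its nearest neighbour is compound 3, separated by a 2.3-fold lower number from compound 2 to compound 3 (0.35 log units; beyond the scatter); the gap to compound 1 is the step of a 5.4-fold higher number from compound 1 to compound 2 (0.73 log units; beyond the scatter) run backwards, the widest spread in the set.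

Compound 4 `CNc1nc(NCCCN(C)C)c2sc(-c3cncnc3)cc2n1` is the next point. Relative to compound 2 the change is pyrimidin-5-yl in place of 4-acetylphenyl on an aromatic carbon. The two steps that bear on it are a 5.4-fold higher number from compound 1 to compound 2 (0.73 log units; beyond the scatter) and a 2.3-fold lower number from compound 2 to compound 3 (0.35 log units; beyond the scatter), both modest and beyond the scatter, and both exchanges at the same aromatic carbon of the five-membered ring with 1 sulfur. Every measured variation at that carbon gives a lower number than compound 2. The new group is a different ring rather than a substituted phenyl, so the measured steps guide only loosely.

A modest decrease is expected, a 2.3-fold lower number from compound 2 to compound 4 (0.36 log units; beyond the scatter). Compound 4 is estimated at 35 uL/min, with a range from 14 uL/min to 80 uL/min.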

Compound 4, intrinsic clearance in a liver preparation (reported as CLH), per the amount of preparation that the assay uses: < 17 uL/min
Compound 4: no number, only a limit; the forecaster's own chance of this, stated with the estimate: 5%; middle value at least 2.0-fold (0.31 log units) away from the limit.
By their numbers in this assay, from the lowest: compound 1; then compound 3; then compound 2.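

Within the data shown here, at the aromatic carbon next to the ring sulfur, the earlier compounds changed only the group carried on a phenyl ring, whereas compound 4 exchanges the whole ring, and in this assay this gives an at least 4.7-fold lower number from compound 2 to compound 4 (0.67 log units; beyond the scatter). Compound 4 gives < 17 uL/min, which is a limit of the assay and not a number, so this step sets only a minimum size: the limit of < 17 uL/min in this assay, at which 1 of the 4 values shown sits. A substituted phenyl is thus not needed at this carbon for a low number, although the order of compound 4 against compound 1 and compound 3 cannot be read from a limit.

The compounds shown leave open whether the lower number in compound 4 goes with the ring nitrogens of pyrimidin-5-yl or with the loss of the acetyl group, since the two changes arrive together. An unsubstituted phenyl or a pyridin-3-yl at the same carbon would separate these two changes, and a carboxylic acid on the phenyl ring would extend the range of groups compared there.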